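Fluoro-to-chloro swap in a sulfonamide oxazole series

This account rests on a few compounds, and the source may have more. Where it says the series, first, only, none or still open, it means among the compounds named here.

Measured so far in a functional assay on HepG2 cells (Homo sapiens) for antiproliferative activity, read by MTT assay, with a stated time of 72 h; on this read-out lower numbers stand for stronger inhibition and higher numbers for weaker inhibition:
- compound 1 `O=S(=O)(c1ccc(-c2cnc(C3CC3)o2)cc1)N1CCCOc2ccc(F)cc21`: 36 nM
- compound 2 `O=S(=O)(c1ccc(-c2cnc(C3CC3)o2)cc1)N1CCOc2ccccc21`: 58 nM
- compound 3 `O=S(=O)(c1ccc(-c2cnc(C3CC3)o2)cc1)N1CCCCc2ccccc21`: 73 nM

Three compounds sharing the same sulfonyl-linked aryl oxazole carry different bicyclic amines. Compound 1 gives the lowest number of the three in this assay. Its gap to compound 2 lies within the usual scatter, so no order between those two can be read. The gap from compound 1 to compound 3 is just beyond the scatter, the only difference among the measured values that stands out at all.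

Compound 4 `O=S(=O)(c1ccc(-c2cnc(C3CC3)o2)cc1)N1CCCOc2ccc(Cl)cc21` keeps the core of compound 1 and differs from it in one place: chloro in place of fluoro on an aromatic carbon. Among the compounds with values here, no measured pair in the set isolates this kind of exchange, so the expectation rests on the unchanged remainder of the molecule.

The step from compound 1 to compound 4 is expected to be small, a 1.1-fold lower number from compound 1 to compound 4 (0.05 log units; within the scatter), not clearly beyond the scatter in either direction. For compound 4 the estimated value in this assay is 32 nM, with a range of 12 nM to 80 nM.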

Compound 4, half-maximal inhibitory concentration: 28 nM
Beside the measured number, compound 4's estimate is 1.1-fold (0.06 log units) above it, and the stated range covers the measured number.
By their numbers in this assay, from the lowest: compounds 4, 1, 2 and 3 (each within the scatter of the next, the first and the last beyond it).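

Chloro in place of fluoro on this aromatic carbon, meta to a fused ring and para to a fused ring, gives a 1.3-fold lower number from compound 1 to compound 4 (0.11 log units; within the scatter) in this assay. Within the data shown here, this is the first pair in the set that isolates a single exchange, and at this position the two halogens cannot be told apart on this read-out, so the position accepts either one. No supporting measurement bears on this result.

Going by these compounds, it remains open how this position reads with hydrogen or with a group other than a halogen, such as methoxy, nitrile or an amine. The compounds shown also leave open whether the same exchange would read alike on the cores of compound 2 and compound 3, neither of which carries a halogen.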